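Ethoxycarbonyl in Place of 3-Hydroxypropyl

A few compounds are considered here, and "the series" means these few. Any claim that something is new, unique, unknown or untested is made for them only; others in the source may bear on it.

In an ADME assay on cells (Peritoneal macrophage cell, Mus musculus) for cytotoxicity, read by MTT assay, with a stated time of 72 h (on this read-out higher numbers stand for lower toxicity in this test and lower numbers for higher toxicity in this test), compound 1 (`CCOC(=O)c1cn(CCCCCCCCCOS(C)(=O)=O)nn1`) gives 983000 nM. Compound 2 (`OCCCc1cn(CCCCCCCCCCCCI)nn1`) gives 66200 nM, the lower of the two numbers and clearly apart from compound 1 beyond the scatter. Compound 3 (`CCOC(=O)c1cn(CCCCCCCCCCCCI)nn1`) has ethoxycarbonyl in place of 3-hydroxypropyl on an aromatic carbon. For the measured compounds named here, compound 1 also bears ethoxycarbonyl, but it differs from compound 3 elsewhere too, so no measured pair isolates this change. No shift beyond the scatter is therefore expected in this assay, and the estimated 1.2-fold higher number from compound 2 to compound 3 (0.08 log units; within the scatter) stays within it. Compound 3 is expected at 80000 nM, within an estimated range of 25000 nM to 250000 nM.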

Compound 3, half-maximal cytotoxic concentration: 93400 nM
For compound 3 the middle estimate is 1.2-fold (0.07 log units) below the measured one; measured number inside the range.
By their numbers in this assay, from the lowest: compounds 2 and 3 (each within the scatter of the next); then compound 1.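

In this assay, ethoxycarbonyl in place of 3-hydroxypropyl on this aromatic carbon gives a 1.4-fold higher number from compound 2 to compound 3 (0.15 log units; within the scatter), so the exchange leaves no shift that can be told from the scatter, even though the hydrogen-bond donor leaves. The change on the chain, nine bonds along from an aromatic nitrogen, does register: 3-iodopropyl in place of (methylsulfonyl)oxy gives an 11-fold lower number from compound 1 to compound 3 (1.02 log units; beyond the scatter), a step beyond the scatter. No measured evidence accounts for either step. From the compounds shown here alone, whether an amine or a carboxylic acid on this aromatic carbon would behave like ethoxycarbonyl remains open, as does the effect of a shorter chain.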